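This account rests on a few compounds, and the source may have more. Where it says the series, first, only, none or still open, it means among the compounds named here.

Compound 1 `C/C(=C\CC/C(C)=C/CC[C@@H]1[C@@]2(C)CCC(=O)C(C)(C)[C@H]2CC[C@@]1(C)O)CC/C=C(\C)C(=O)OCc1cn(-c2ccccc2C)nn1` gives in an ADME assay on L132 cells (Homo sapiens) for cytotoxicity, read by MTT assay, with a stated time of 48 h (a lower number here means a stronger inhibitor, a higher number a weaker inhibitor), a value of > 150000 nM, which is a limit of the assay and not a number.
Compound 2 `C/C(=C\CC/C(C)=C/CC[C@@H]1[C@@]2(C)CCC(=O)C(C)(C)[C@H]2CC[C@@]1(C)O)CC/C=C(\C)C(=O)OCc1cn(-c2ccc(C(F)(F)F)cc2)nn1` gives in this assay a value of > 150000 nM, again a limit rather than a number.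
Compound 3 `C/C(=C\CC/C(C)=C/CC[C@@H]1[C@@]2(C)CCC(=O)C(C)(C)[C@H]2CC[C@@]1(C)O)CC/C=C(\C)C(=O)OCc1cn(C[C@@H]2O[C@H](n3ccc(=O)[nH]c3=O)[C@H]3OC(C)(C)O[C@H]32)nn1` gives in this assay a value of > 150000 nM, also a limit.

Compound 1 therefore stands nowhere that can be ranked: only a limit is known for it, and the two other values shown are limits as well. The account now turns to compound 4 `C/C(=C\CC/C(C)=C/CC[C@@H]1[C@@]2(C)CCC(=O)C(C)(C)[C@H]2CC[C@@]1(C)O)CC/C=C(\C)C(=O)OCc1cn(-c2ccc([N+](=O)[O-])cc2)nn1`, which differs from compound 1 by 4-nitrophenyl in place of 2-methylphenyl on an aromatic nitrogen.

Within the data shown here, the one measured step at the same place, a step that the two limits leave unreadable from compound 1 to compound 2, cannot be read, since both of its ends are limits. Among the measured compounds shown here, the only bearing evidence is the limit of > 150000 nM in this assay, at which 3 of the 3 values shown sit, and because of the limit of > 150000 nM in this assay, at which 3 of the 3 values shown sit, no size or direction of step can be assigned in this assay for the change from compound 1 to compound 4.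

The step that the limit leaves unreadable from compound 1 to compound 4 is thus expected to be none beyond the scatter, with the result most likely again a limit. Compound 4 is estimated at 200000 nM in this assay, within a range of 150000 nM to 400000 nM.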

Compound 4, half-maximal inhibitory concentration: > 150000 nM
Compound 4 ended at the assay's limit (the forecaster's own chance of this, stated with the estimate: 85%); the middle value does not contradict the limit.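

Among these compounds, no step among compound 1, compound 2 and compound 4 can be read in this assay, since each of their values is a limit and not a number: the limit of > 150000 nM in this assay, at which 4 of the 4 values shown sit. The compounds shown leave open whether any change on the aromatic nitrogen alters the value in this assay, and by how much.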